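Trimethoxy to dimethoxy: expected effect on growth inhibition

The source may report more compounds than this note shows. Statements on the series, on what has been measured and on what is new or still open speak of the compounds shown alone.

Compound 2 `COc1cc(-c2cc(/C=C/C(=O)c3ccc(N)cc3)[nH]n2)cc(OC)c1OC` gives 4330 nM in a functional assay on A498 cells (Homo sapiens) for inhibition, read by sulforhodamine B assay, with a stated time of 48 h (a higher number here means a weaker inhibitor of growth, a lower number a stronger inhibitor of growth), the second highest of the three numbers measured. Compound 3 `COc1ccc(C(=O)/C=C/c2cc(-c3cc(OC)c(OC)c(OC)c3)n[nH]2)cc1` gives 3940 nM and compound 1 `COc1ccc(-c2cc(/C=C/C(=O)c3ccc(N)cc3)[nH]n2)cc1` gives 4950 nM, both within the scatter of compound 2. Compound 4 `COc1ccc(-c2cc(/C=C/C(=O)c3ccc(N)cc3)[nH]n2)cc1OC` differs from compound 2 by hydrogen in place of methoxy on an aromatic carbon. For the measured compounds named here, the only single-place step measured, a 1.1-fold lower number from compound 2 to compound 3 (0.04 log units; within the scatter), concerns a different group and lies within the scatter. Compound 1 and compound 2 differ by two methoxy groups yet agree within the scatter, and compound 4 carries fewer methoxy groups than compound 2 and more than compound 1. No step beyond the scatter is therefore expected in this assay. Compound 4 is estimated at 4600 nM with a range of 2300 nM to 9200 nM. The expected step is a 1.1-fold higher number from compound 2 to compound 4 (0.03 log units; within the scatter).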

Compound 4, concentration for total growth inhibition: 7090 nM
Estimate against measurement, compound 4: 1.5-fold (0.19 log units) below, within the range that was stated.
By their numbers in this assay, from the lowest: compounds 3, 2, 1 and 4 (each within the scatter of the next).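

In this assay, hydrogen in place of methoxy on the aromatic carbon ortho to a methoxy group gives a 1.6-fold higher number from compound 2 to compound 4 (0.21 log units; within the scatter), and methoxy in place of hydrogen gives a 1.4-fold higher number from compound 1 to compound 4 (0.16 log units; within the scatter). Both steps lie within the scatter, so these single-place changes on the methoxy-bearing ring resolve no difference between hydrogen and methoxy in this read-out. Nothing available bears on a cause for these steps. On these data alone, whether a hydroxyl, an ethoxy or a chlorine atom on this carbon would give a step beyond the scatter remains open.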